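Extending the amine side of the shared core with an amide chain

The source may hold more compounds than are shown below. What is called first, only, known or untested is meant among the compounds shown, and "the series" means these compounds.

Within the data shown here, compound 2 `CC[C@H]1OC(=O)[C@H](C)[C@@H](O)[C@H](C)[C@@H](O[C@@H]2O[C@H](C)C[C@H](N(C)C)[C@H]2O)[C@](C)(O)C[C@@H](C)CN(C)[C@H](C)[C@@H](O)[C@]1(C)O` has the lower of the two numbers measured so far. In a physicochemical assay for lipophilicity, read by HPLC, measured as chromatographic lipophilicity, at pH 7.4 (on this read-out lower numbers stand for lower lipophilicity and higher numbers for higher lipophilicity), compound 2 gives 1.35, while compound 1 `CC[C@H]1OC(=O)[C@H](C)[C@@H](OCCCNC(=O)C2CCC2)[C@H](C)[C@@H](O[C@@H]2O[C@H](C)C[C@H](N(C)C)[C@H]2O)[C@](C)(O)C[C@@H](C)CN(C)[C@H](C)[C@@H](O)[C@]1(C)O` gives 1.78. Among the measured compounds shown here, the one measured step, a number 0.43 log units lower from compound 1 to compound 2 (beyond the scatter), removed a 3-((cyclobutylcarbonyl)amino)propyl from an oxygen on a saturated carbon. Compound 3 `CCCCCCCC(=O)NCCCN(C)[C@H]1C[C@@H](C)O[C@@H](O[C@@H]2[C@@H](C)[C@H](O)[C@@H](C)C(=O)O[C@H](CC)[C@@](C)(O)[C@H](O)[C@@H](C)N(C)C[C@H](C)C[C@@]2(C)O)[C@@H]1O` carries the change (2-((heptylcarbonyl)amino)ethyl in place of hydrogen on a saturated chain carbon bound to an amine nitrogen). The measured step bears on this only loosely: it concerns a shorter amide-bearing chain at a different place, but it shows that adding such a chain moved this assay upward by a modest amount beyond the scatter. With a longer chain entering, a larger upward step is expected, a number 1.05 log units higher from compound 2 to compound 3 (beyond the scatter), giving an estimated value for compound 3 of 2.4, within a range from 1.9 to 2.9.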

Compound 3, distribution coefficient: 4.84
Compound 3: middle estimate off by 2.44 log units, on the low side; the whole stated range lies below it.
By their numbers in this assay, from the lowest: compound 2; then compound 1; then compound 3.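

At this place, on a saturated chain carbon bound to an amine nitrogen, the entry of 2-((heptylcarbonyl)amino)ethyl gives a number 3.49 log units higher from compound 2 to compound 3 (beyond the scatter) in this assay. The earlier compounds had shown only a modest step, a number 0.43 log units lower from compound 1 to compound 2 (beyond the scatter), with a different chain at a different place, and this result shows that a chain carrying an amide can go with a far larger change in this read-out. Nothing available here accounts for the size of the new step.

The compounds shown leave open how much of the step belongs to the length of the heptyl part and how much to the amide, which a shorter chain at this place would help to separate. They also leave open how the read-out would respond to a chain ending in an amine or a carboxylic acid.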